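Ethynyl to 1,1-difluoroethyl: notes on the next step

A few compounds are considered here, and "the series" means these few. Any claim that something is new, unique, unknown or untested is made for them only; others in the source may bear on it.

The series is followed in an ADME assay on microsomes from liver (Canis lupus familiaris) for metabolic stability, read by LC-MS, using NADPH, with a stated time of 10 min, tested at 0.1 uM; on this read-out higher numbers stand for fast clearance and lower numbers for slow clearance. Here compound 1 (`CC1SC(c2cccc(C(=O)NCCCCc3ccccc3)c2)N(c2ccc(C3CC3)cc2)C1=O`) gives 1750 mL.min-1.g-1, compound 2 (`O=C(NCCCCc1ccccc1)c1cccc(C2SCC(=O)N2c2ccccn2)c1`) gives 492 mL.min-1.g-1, and compound 3 (`C#Cc1cccc(N2C(=O)CSC2c2cccc(C(=O)NCCCCc3ccccc3)c2)c1`) gives 973 mL.min-1.g-1. Compound 3 holds the middle place among these three numbers, and its gaps to compound 1 and to compound 2 both lie within the scatter.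

The next compound is compound 4 (`CC(F)(F)c1cccc(N2C(=O)CSC2c2cccc(C(=O)NCCCCc3ccccc3)c2)c1`), with 1,1-difluoroethyl in place of ethynyl on an aromatic carbon, meta to a large group: 1,1-difluoroethyl in place of ethynyl on an aromatic carbon.

Among the measured compounds shown here, only one measured step bears on this change, and only indirectly: a 2.0-fold higher number from compound 2 to compound 3 (0.30 log units; within the scatter), with 3-ethynylphenyl in place of pyridin-2-yl on an amide-type nitrogen in a ring. For the measured compounds named here, no measured pair replaces ethynyl alone, and no measured compound carries 1,1-difluoroethyl. The data therefore give no direction, and no step beyond the scatter is expected in this assay. The expected step is a 1.1-fold higher number from compound 3 to compound 4 (0.05 log units; within the scatter). For compound 4 the estimated value is 1100 mL.min-1.g-1, with an expected range from 520 mL.min-1.g-1 to 2300 mL.min-1.g-1.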

Compound 4, intrinsic clearance in microsomes: 912 mL.min-1.g-1
Estimate against measurement, compound 4: 1.2-fold (0.08 log units) above; low and high end bracket the measured number.
By their numbers in this assay, from the lowest: compounds 2, 4, 3 and 1 (each within the scatter of the next, the first and the last beyond it).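

Working notes on the ethynyl position. In this assay, among the compounds shown here, the first direct reading of this position is a 1.1-fold lower number from compound 3 to compound 4 (0.03 log units; within the scatter) and it shows that 1,1-difluoroethyl, with 4 heavy atoms including 2 fluorine, can replace ethynyl, with 2 heavy atoms and a triple bond, on an aromatic carbon, meta to a large group, without a step beyond the scatter. The larger exchange on the amide-type nitrogen in a ring gives a 1.9-fold higher number from compound 2 to compound 4 (0.27 log units; within the scatter) and so also stays within the scatter, as does the earlier 2.0-fold higher number from compound 2 to compound 3 (0.30 log units; within the scatter), which means that neither substituted phenyl group is separated from pyridin-2-yl on this read-out. Nothing shown gives a measured reason for these small steps.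

Going by these compounds, whether an amine or a carboxylic acid on the same aromatic carbon would move the clearance number beyond the scatter stays open, and so does the effect of either group at any other place on that ring. Compound 1 differs from compound 3 and compound 4 in more than one place, so the separate contributions of its cyclopropyl group and its extra methyl on the core also stay unresolved.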